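This account rests on a few compounds, and the source may have more. Where it says the series, first, only, none or still open, it means among the compounds named here.

Among the compounds with values here, the two compounds measured so far share one core. Compound 1 `O=C1OC(c2ccc(Cl)cc2)=C/C1=C\c1ccccc1` carries a hydrogen at the position in question, and compound 2 `O=C1OC(c2ccc(Cl)cc2)=C/C1=C\c1ccc(Cl)cc1` carries a chloro there. In a functional assay on the whole organism (strain Wistar) for inhibition, with Rattus norvegicus as the target, with stated times of 30 min and 2 h, at a dose of 20 mg/kg by the oral route (on this read-out higher numbers stand for more inhibition at the one dose given (going by the name of the read-out) and lower numbers for less inhibition), compound 1 gives 18.9%, whereas compound 2 gives 40%. Within the data shown here, the only step available is a number 21.1 percentage points higher from compound 1 to compound 2 (beyond the scatter), so compound 2 stands as the higher of the two numbers, and its nearest neighbour is compound 1.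

Compound 3 `O=C1OC(c2ccc(Cl)cc2)=C/C1=C\c1ccc([N+](=O)[O-])cc1` is the next member. It differs from compound 2 in one place: nitro in place of chloro on an aromatic carbon. Among the measured compounds shown here, no measured pair shows nitro replacing chloro, so the one step at hand, from hydrogen to chloro, bears on this change only loosely: it tells that a substituent at the position para to a large group goes with a modestly higher number in this assay, not how one substituent compares with another.

For the measured compounds named here, with no direct precedent, the estimated change in this assay is a number 4 percentage points lower from compound 2 to compound 3 (within the scatter), that is, no step beyond the scatter is expected. Compound 3 is therefore expected to give about 36%, with a range from 15% to 58%.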

Compound 3, a percentage reported as inhibition, in the whole organism at one dose (the size of the read-out at that dose, not a potency): 4%
Estimate against measurement, compound 3: 32 percentage points above, and the stated range ends above it.
By their numbers in this assay, from the lowest: compound 3; then compound 1; then compound 2.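

The result shows that in this assay the outcome at this position, on an aromatic carbon para to a large group, depends on which substituent is present and not merely on whether one is present. Nitro in place of chloro gives a number 36 percentage points lower from compound 2 to compound 3 (beyond the scatter) and is a large step, while nitro in place of hydrogen gives a number 14.9 percentage points lower from compound 1 to compound 3 (beyond the scatter) and is a modest one. Set beside chloro in place of hydrogen, which gives a number 21.1 percentage points higher from compound 1 to compound 2 (beyond the scatter) as its step, these results show the two substituents moving the number in opposite directions from hydrogen, so the earlier idea that a substituent here goes with a higher number holds for compound 2 and fails for compound 3.

As far as these compounds go, whether an amine, a methoxy group or a carboxylic acid at this place would fall nearer chloro or nearer nitro remains open, and three compounds cannot establish a wider order among substituents. Nothing in the available data explains why chloro and nitro part so widely in this whole-animal read-out.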